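Nitro on the phenyl of compound 1

The source may hold more compounds than are shown below. What is called first, only, known or untested is meant among the compounds shown, and "the series" means these compounds.

Compound 1 `CCOC(=O)c1cnc(-c2ccccc2)nc1NN1C(=O)C=C(C)C1=O` is the reference point of this small set. In a functional assay on Jurkat cells for inhibition of nuclear factor NF-kappa-B complex (Homo sapiens) (a higher number here means a weaker inhibitor, a lower number a stronger inhibitor), compound 1 gives 100 nM, the lowest number of the three measured. The other two replace the phenyl: compound 2 `CCOC(=O)c1cnc(-c2cnc3ccccc3c2)nc1NN1C(=O)C=C(C)C1=O` gives 6000 nM and compound 3 `CCOC(=O)c1cnc(-c2csc(C)n2)nc1NN1C(=O)C=C(C)C1=O` gives 8000 nM, that is a 60-fold higher number from compound 1 to compound 2 (1.78 log units; beyond the scatter) and an 80-fold higher number from compound 1 to compound 3 (1.90 log units; beyond the scatter), both large losses; between them, a 1.3-fold higher number from compound 2 to compound 3 (0.12 log units; within the scatter).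

Compound 4 `CCOC(=O)c1cnc(-c2cccc([N+](=O)[O-])c2)nc1NN1C(=O)C=C(C)C1=O` keeps the phenyl of compound 1 and differs from it by nitro in place of hydrogen on an aromatic carbon, placed on an aromatic carbon of a six-membered aromatic ring of carbon only, meta to a large group. For the measured compounds named here, no measured step touches a substituent on this ring; the two measured steps only show that leaving the phenyl altogether costs a lot, which does not apply here. The expectation is therefore a step of modest size in this assay, direction uncertain, a 1.5-fold higher number from compound 1 to compound 4 (0.18 log units; within the scatter). Compound 4 is estimated at 150 nM, with a range of 40 nM to 600 nM.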

Compound 4, half-maximal inhibitory concentration: 7000 nM
Compound 4: middle estimate off by 47-fold (1.67 log units), on the low side, and the stated range ends below it.
By their numbers in this assay, from the lowest: compound 1; then compounds 2, 4 and 3 (each within the scatter of the next).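

Placing nitro on the phenyl, on an aromatic carbon meta to a large group, is a large change in this assay, with a 70-fold higher number from compound 1 to compound 4 (1.85 log units; beyond the scatter), so the loss seen earlier on leaving the phenyl also appears with the phenyl kept. The level reached with nitro matches that of the two ring replacements, with a 1.1-fold lower number from compound 3 to compound 4 (0.06 log units; within the scatter) and a 1.2-fold higher number from compound 2 to compound 4 (0.07 log units; within the scatter), so all three changes end at one level and only the unsubstituted phenyl stands apart from it. Nothing available bears on why nitro costs this much.

Going by these compounds, whether the loss belongs to nitro itself or to any added group on this carbon stays open; a fluorine, a methyl or an amine in the same place would separate the two. Also open, on these data alone, is whether nitro on another carbon of the phenyl carries the same cost.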